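A few compounds are considered here, and "the series" means these few. Any claim that something is new, unique, unknown or untested is made for them only; others in the source may bear on it.

Of the compounds shown here, three sharing one core have been measured in a functional assay on SK-BR-3 cells (Homo sapiens) for cytotoxicity, read by MTT assay, with a stated time of 72 h; on this read-out higher numbers stand for weaker inhibition and lower numbers for stronger inhibition. Compound 1, `N[C@H]1CC[C@H](NC(=O)c2nc(Br)c3cccnc3c2NCc2ccc(F)cc2)CC1`, gives 2800 nM in this assay. Compound 2, `COC(=O)CNc1c(C(=O)NCc2ccc(F)cc2)nc(Br)c2cccnc12`, gives 1000 nM in this assay, the lowest of the three numbers. Compound 3, `N[C@H]1CC[C@H](Nc2c(C(=O)NC3CCCCC3)nc(Br)c3cccnc23)CC1`, gives 4200 nM in this assay. Compound 2 therefore stands as the strongest of the three: its gap to compound 1 and its gap to compound 3 both lie beyond the usual scatter of repeated measurements. The three compounds differ from one another in more than one place, so no single change can be read from their values.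

Compound 4, `Nc1cccc(Nc2c(C(=O)NCc3ccc(F)cc3)nc(Br)c3cccnc23)c1`, has not yet been measured. It differs from compound 2 in one place: 3-aminophenyl in place of (methoxycarbonyl)methyl on a nitrogen on an aromatic ring. Going by the values given here, no measured pair shows this change on its own, and none of the measured pairs isolates any single change, so there is no step to lean on. The step from compound 2 to compound 4 in this assay is expected to be small, a 1.2-fold higher number from compound 2 to compound 4 (0.08 log units; within the scatter), and may fall within the scatter in either direction. Compound 4 is estimated to give about 1200 nM in this assay, with a range from 400 nM to 4000 nM.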

Compound 4, half-maximal inhibitory concentration: > 10000 nM
Compound 4: no number, only a limit; the forecaster's own chance of this, stated with the estimate: 10%; at least 8.3-fold (0.92 log units) between middle value and limit.
By their numbers in this assay, from the lowest: compound 2; then compounds 1 and 3 (each within the scatter of the next). At a limit, above all of these: compound 4.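

Going by these compounds alone, compound 4 gives the first step here that isolates a single change: with 3-aminophenyl in place of (methoxycarbonyl)methyl on a nitrogen on an aromatic ring, this assay shows an at least 10-fold higher number from compound 2 to compound 4 (1.00 log units; beyond the scatter). In this assay compound 4 gives > 10000 nM, which is a limit of the assay and not a number, and the step rests on that limit: the limit of > 10000 nM in this assay, at which 1 of the 4 values shown sits. The earlier compounds shown here differ from one another in more than one place and could say nothing about this position alone, whereas this step shows that the group on this nitrogen matters and that swapping the open chain for a six-membered aromatic ring of carbon only is not a neutral exchange here.

This single step changes the ring and the amino group together, so it does not tell which of the two goes with the weaker result, and a plain phenyl would be needed to separate them. From the compounds shown here alone, how a carboxylic acid in place of the methyl ester, or a longer chain on this nitrogen, would stand in this assay also remains open.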